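Notes on the step from compound 2 to compound 3

The compounds below may be only part of what the source reports. "The series", "measured", "known", "first", "only" and "open" are said of these compounds alone.

- compound 1 `Cc1ccc(S(=O)(=O)Cc2nc(Nc3ccc(F)cc3)c3ccccc3n2)cc1`: > 20000 nM (a limit)
- compound 2 `Cc1ccc(S(=O)(=O)Cc2nc(Nc3cccc(Br)c3)c3ccccc3n2)cc1`: > 15000 nM (a limit)

Both entries come from a functional assay on K562 cells (Homo sapiens) for cytotoxicity, read by flow cytometry, with a stated time of 72 h; on this read-out higher numbers stand for weaker inhibition and lower numbers for stronger inhibition. Compound 2 stands at a limit, > 15000 nM, so it offers no number to work from. Compound 1 also stands at a limit, > 20000 nM. For the measured compounds named here, no value is therefore a true number so far.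

The next compound is compound 3 `Cc1ccc(S(=O)(=O)Cc2nc(Nc3ccccc3Cl)c3ccccc3n2)cc1`, which carries 2-chlorophenyl in place of 3-bromophenyl on a nitrogen on an aromatic ring.

Going by the values given here, one measured step bears on this change, as it alters the group at the same place: a step that the two limits leave unreadable from compound 1 to compound 2. It gives no size to carry over, so no step beyond the scatter is expected in this assay, and no direction can be argued. The expectation rests on compound 2 with its limit of > 15000 nM, and another limit is the likeliest report. The estimated step is a step that the limit leaves unreadable from compound 2 to compound 3. For compound 3 the expected value is 20000 nM, with an estimated range of 10000 nM to 40000 nM.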

Compound 3, half-maximal inhibitory concentration: 24000 nM
Compound 3: the middle estimate sits 1.2-fold (0.08 log units) below what was measured; the measured number falls inside the stated range.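

In this assay, for the compounds shown here, neither the step from compound 2 to compound 3 nor the one from compound 1 to compound 3 can be read, since each starts from a limit. Compound 3 gives 24000 nM. The compounds shown leave open how far a change of the aryl group on the nitrogen moves this assay.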